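Ester to Acid on an Oxime Ether Side Chain

The compounds below may be only part of what the source reports. "The series", "measured", "known", "first", "only" and "open" are said of these compounds alone.

The compounds measured so far:
compound 1 `COc1ccc(/C(=N/O)c2cccc3ccccc23)c(OC)c1OC`, in a functional assay on MCF7 cells (Homo sapiens) for inhibition, read by sulforhodamine B assay, with a stated time of 48 h (a higher number here means a weaker inhibitor, a lower number a stronger inhibitor), compound 1 gives > 20000 nM, a limit of the assay.
compound 2 `CCOC(=O)CO/N=C(/c1ccc(OC)c(OC)c1OC)c1cccc2ccccc12`, in this assay compound 2 gives > 20000 nM, again a limit of the assay.
compound 3 `COc1ccc(C(c2ccccc2O)c2cccc3ccccc23)c(OC)c1OC`, in this assay compound 3 gives 16600 nM.

Compound 2 therefore stands at the limit of this assay, with no number of its own. Among the measured compounds shown here, the one measured step that touches it, a step that the two limits leave unreadable from compound 1 to compound 2, is unreadable, since both ends are limits; the only real number in the set belongs to compound 3, and even that lies close to the limit. Compound 4 `COc1ccc(/C(=N/OCC(=O)O)c2cccc3ccccc23)c(OC)c1OC` differs from compound 2 in one place: hydrogen in place of ethyl on an oxygen next to a carbonyl group.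

For the measured compounds named here, no measured step bears on this change, so the expectation rests on where the values sit: the limit of > 20000 nM in this assay, at which 2 of the 3 values shown sit. With nothing pointing toward a readable gain, compound 4 is expected to remain at the limit, an expected step that the limit leaves unreadable from compound 2 to compound 4 of no readable size. The estimate for compound 4 in this assay is 30000 nM, within a range of 15000 nM to 80000 nM, with the reported value most likely a limit.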

Compound 4, half-maximal inhibitory concentration: > 20000 nM
Compound 4 ended at the assay's limit; the forecaster's own chance of this, stated with the estimate: 80%; the middle value does not contradict the limit.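

In this assay compound 4 gives > 20000 nM, a limit of the assay. Among the compounds shown here, compound 1 and compound 2 also stand at limits, so no step from either to compound 4 can be read: the limit of > 20000 nM in this assay, at which 3 of the 4 values shown sit. The compounds shown leave open whether compound 2 and compound 4 differ at all in this assay, as neither has a number of its own.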